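The source may hold more compounds than are shown below. What is called first, only, known or untested is meant among the compounds shown, and "the series" means these compounds.

Of the compounds shown here, three have so far been tested in a functional assay on MCF7 cells (Homo sapiens) for cytotoxicity, read by MTT assay, with a stated time of 48 h; a higher number here means a weaker inhibitor, a lower number a stronger inhibitor. Compound 1 `C=CC(=C)[C@@H](O)C[C@H]1C(=C)CC[C@@H]2[C@]1(C)CCC[C@]2(C)C(=O)O` gives only a limit of the assay here, > 40000 nM. Compound 3 `C=C/C(C)=C/C[C@H]1C(=C)CC[C@@H]2[C@]1(C)CCC[C@]2(C)C=O` likewise gives a limit, > 40000 nM. Compound 2 `C=CC(=C)CC[C@@H]1[C@@]2(C)CCC[C@](C)(COC(=O)/C=C/c3ccc(O)c(OC)c3)[C@@H]2CC[C@@]1(C)O` gives a measured value in this assay of 13500 nM. Compound 1 thus sits with compound 3 at the weak end, at the limit of > 40000 nM in this assay, at which 2 of the 3 values shown sit. Compound 4 `C=C[C@]1(C)O[C@H]1C[C@H]1C(=C)CC[C@@H]2[C@]1(C)CCC[C@]2(C)C(=O)O` differs from compound 1 by a group of 6 heavy atoms (5 carbon, 1 oxygen; one three-membered non-aromatic ring with 1 hetero atom) in place of a group of 6 heavy atoms (5 carbon, 1 oxygen; no ring), on a saturated chain carbon bound to a saturated ring carbon. Among the compounds with values here, no pair of measured compounds differing in a single place is available, so the size of this step cannot be read from the data. The shared core of compound 1 is kept, and the step of a number no higher from compound 1 to compound 4 (the limit leaves the size open) is expected to stay within the scatter. Compound 4 is estimated to give 40000 nM in this assay, between 20000 nM and 80000 nM.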

Compound 4, half-maximal inhibitory concentration: > 40000 nM
Compound 4 was reported as a limit (the forecaster's own chance of this, stated with the estimate: 70%); the middle value sits exactly at the limit.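

Within the data shown here, compound 1 and compound 4 both give only a limit of the assay, so no step between them can be read. From the compounds shown here alone, how far the three-membered ring of compound 4 shifts the value stays open.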